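Lengthening the side chain on a silent scaffold

The source may hold more compounds than are shown below. What is called first, only, known or untested is meant among the compounds shown, and "the series" means these compounds.

- compound 1 `CN(C)CCCCn1c(N)c(-c2nc3ccccc3s2)c2nc(C#N)c(C#N)nc21`: 2740 nM
- compound 2 `CN(C)CCn1c(N)c(-c2nc3ccccc3n2C)c2nc(C#N)c(C#N)nc21`: > 50000 nM
- compound 3 `CCN(CC)CCn1c(N)c(-c2nc3ccccc3n2C)c2nc(C#N)c(C#N)nc21`: > 50000 nM

In a functional assay on cells (Homo sapiens) for antiproliferative activity, read by MTT assay, with a stated time of 48 h (on this read-out lower numbers stand for stronger inhibition and higher numbers for weaker inhibition), compound 3 gives > 50000 nM, which is a limit and not a number. Compound 2 also gives only a limit, > 50000 nM. Within the data shown here, the one measured step, a step that the two limits leave unreadable from compound 2 to compound 3, therefore offers no size to carry forward.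

Compound 4 `CN(C)CCCCn1c(N)c(-c2nc3ccccc3n2C)c2nc(C#N)c(C#N)nc21` differs from compound 3 as follows: 2-(dimethylamino)ethyl in place of diethylamino on a saturated chain carbon, two bonds along the chain from an aromatic nitrogen. Read one bond further out, 4-(dimethylamino)butyl replaces 2-(diethylamino)ethyl.

Compound 1 carries that same 4-(dimethylamino)butyl chain on a different core and gives 2740 nM, so a move towards stronger inhibition is expected. For compound 4 a limit remains possible. The expected change is an at least 4.1-fold lower number from compound 3 to compound 4 (0.61 log units; beyond the scatter). For compound 4 the estimate is 12000 nM, with an expected range of 3000 nM to 50000 nM.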

Compound 4, half-maximal inhibitory concentration: 1790 nM
Estimate against measurement, compound 4: 6.7-fold (0.83 log units) above, outside the stated range (below it).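

Replacing the shorter chains with 4-(dimethylamino)butyl on the shared core gives an at least 27-fold lower number from compound 3 to compound 4 (1.44 log units; beyond the scatter) and an at least 27-fold lower number from compound 2 to compound 4 (1.44 log units; beyond the scatter), so this position is not silent in every form. Both steps start from a limit and not from a number, so their full size stays unknown: the limit of > 50000 nM in this assay, at which 2 of the 4 values shown sit.

With that chain in place, the two ring groups cannot be told apart: a 1.5-fold lower number from compound 1 to compound 4 (0.18 log units; within the scatter).

The compounds shown leave open whether chain length alone accounts for the drop. A 3-(dimethylamino)propyl chain, a longer chain or a 4-(diethylamino)butyl chain would test this.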